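The compounds below may be only part of what the source reports. "The series", "measured", "known", "first", "only" and "open" are said of these compounds alone.

Compound 3 `CC(=O)N1CCC(NC(=O)N2CCC(c3nc(-c4ccc5ccccc5n4)no3)CC2)CC1` gives 500 nM in a functional assay on Shh Light II cells (Mus musculus) for inhibition, read by a luciferase reporter; on this read-out higher numbers stand for weaker inhibition and lower numbers for stronger inhibition; among the three compounds measured it carries the lowest number, though compound 1 `O=C(Nc1ccccc1Cl)N1CCC(c2nc(-c3ccc4ccccc4n3)no2)CC1`, with 510 nM, sits beside it, as a 1.0-fold lower number from compound 1 to compound 3 (0.01 log units; within the scatter) shows, while compound 2 `O=C(N1CCC(c2nc(-c3ccc4ccccc4n3)no2)CC1)N1CCCc2ccccc21` gives 2300 nM and a 4.6-fold lower number from compound 2 to compound 3 (0.66 log units; beyond the scatter) separates them. Compound 4 `O=C(Nc1cccnc1Cl)N1CCC(c2nc(-c3ccc4ccccc4n3)no2)CC1` differs from compound 3 in one place: 2-chloropyridin-3-yl in place of 1-acetylpiperidin-4-yl on an amide-type nitrogen. Going by the values given here, the step that bears on this is the one between compound 1 and compound 3, where the same position held 2-chlorophenyl, a close relative of 2-chloropyridin-3-yl, and a 1.0-fold lower number from compound 1 to compound 3 (0.01 log units; within the scatter) stayed within the scatter. The change is therefore expected to make no difference beyond the scatter, as no change at the digits printed from compound 3 to compound 4 (within the scatter). Compound 4 is estimated at 500 nM, with a range from 200 nM to 1300 nM.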

Compound 4, half-maximal inhibitory concentration: 1600 nM
The estimate for compound 4 lay 3.2-fold (0.51 log units) below the measured number, and the stated range ends below it.
By their numbers in this assay, from the lowest: compounds 3 and 1 (each within the scatter of the next); then compounds 4 and 2 (each within the scatter of the next).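

Groups that look alike are not interchangeable on this amide-type nitrogen: 2-chloropyridin-3-yl in place of 2-chlorophenyl gives a 3.1-fold higher number from compound 1 to compound 4 (0.50 log units; beyond the scatter) on this read-out. The step from the unrelated 1-acetylpiperidin-4-yl group is of similar size, a 3.2-fold higher number from compound 3 to compound 4 (0.51 log units; beyond the scatter) for the same new group, so resemblance between groups did not predict the outcome here. Meanwhile, a 1.4-fold lower number from compound 2 to compound 4 (0.16 log units; within the scatter) places compound 4 level with compound 2. Whether 2-fluorophenyl or 2-chloropyridin-4-yl on this nitrogen would keep the number of compound 1 stays open, and no measurement shown explains the step caused by the pyridine ring.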